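Ring amine to aryl amide on the imidazole nitrogen

The compounds below may be only part of what the source reports. "The series", "measured", "known", "first", "only" and "open" are said of these compounds alone.

Measured so far in a functional assay on HCC827 cells (Homo sapiens) for antiproliferative activity, read by MTT assay, with a stated time of 72 h; on this read-out higher numbers stand for weaker inhibition and lower numbers for stronger inhibition:
- compound 1 `CN1CCN(c2ccc(Nc3ncc4nc(Nc5ccccc5)n([C@H]5CCNC5)c4n3)cc2)CC1`: 530 nM
- compound 2 `CN1CCN(c2ccc(Nc3ncc4nc(Nc5ccc(F)cc5)n([C@@H]5CCCNC5)c4n3)cc2)CC1`: 120 nM
- compound 3 `CN1CCN(c2ccc(Nc3ncc4nc(Nc5ccccc5)n([C@H]5CCN(S(=O)(=O)C6CC6)C5)c4n3)cc2)CC1`: 1.6 nM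

Compound 2 stands second highest of the three numbers; compound 1 gives a higher number and compound 3 a much lower one. Compound 4 `CN1CCN(c2ccc(Nc3ncc4nc(Nc5ccc(F)cc5)n(-c5cccc(NC(=O)CO)c5)c4n3)cc2)CC1` is not yet measured. Its change from compound 2 is 3-(((hydroxymethyl)carbonyl)amino)phenyl in place of piperidin-3-yl on an aromatic nitrogen. For the measured compounds named here, the only single-point step known, a 330-fold lower number from compound 1 to compound 3 (2.52 log units; beyond the scatter), concerns a substituent on the ring amine nitrogen, not its replacement by an aryl group, so it bears only loosely here. With the ring amine removed altogether, the expected step of a 3.0-fold lower number from compound 2 to compound 4 (0.48 log units; beyond the scatter) is a moderate gain with wide uncertainty. Compound 4 is therefore estimated at 40 nM, within 5 nM to 300 nM.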

Compound 4, half-maximal inhibitory concentration: 7.5 nM
Beside the measured number, compound 4's estimate is 5.3-fold (0.73 log units) above it; the measured number falls inside the stated range.
By their numbers in this assay, from the lowest: compound 3; then compound 4; then compound 2; then compound 1.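

In this assay the step of a 16-fold lower number from compound 2 to compound 4 (1.20 log units; beyond the scatter) shows that a low number on this aromatic nitrogen does not require a ring amine, since 3-(((hydroxymethyl)carbonyl)amino)phenyl replaces piperidin-3-yl outright. The earlier step of a 330-fold lower number from compound 1 to compound 3 (2.52 log units; beyond the scatter) showed only a change on the ring amine nitrogen, with the ring itself kept. No measurement available here accounts for the size of the new step.

The step swaps ring and side chain together, so the share of each cannot be separated. As far as these compounds go, whether an unsubstituted phenyl, or an amine or carboxylic acid in place of the hydroxymethyl, would hold this level remains open.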